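Second chloro on the core of the meta-substituted benzyl series

The compounds below may be only part of what the source reports. "The series", "measured", "known", "first", "only" and "open" are said of these compounds alone.

Three purine-type compounds with a chloromethylbenzyl arm have been run in a functional assay on OVCAR-4 cells (Homo sapiens) for cytotoxicity, read by sulforhodamine B assay, with a stated time of 48 h; a higher number here means a weaker inhibitor of growth, a lower number a stronger inhibitor of growth. Compound 1 `ClCc1ccc(Cn2cnc3c(Cl)ncnc32)cc1` gives 2450 nM. Compound 2 `ClCc1cccc(Cn2cnc3c(Cl)ncnc32)c1` gives 2340 nM. Compound 3 `ClCc1ccc(Cn2cnc3nc(Cl)nc(Cl)c32)cc1` carries a further chloro group on its core relative to compound 1; in this assay compound 3 gives 2080 nM. On these numbers compound 2 holds the second highest of the three values; its nearest neighbour is compound 1, within the scatter, and its furthest is compound 3, also within the scatter, so the three sit together.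

Compound 4 `ClCc1cccc(Cn2cnc3c(Cl)nc(Cl)nc32)c1` differs from compound 2 by chloro in place of hydrogen on an aromatic carbon. Going by the values given here, no measured pair isolates this change in the meta series. The values of compound 1 and compound 3 show the same sort of core substitution leaving the number close to where it started. The step from compound 2 to compound 4 in this assay is therefore expected to stay within the scatter, with no clear direction: a 1.1-fold lower number from compound 2 to compound 4 (0.05 log units; within the scatter). Compound 4 is estimated at 2100 nM, in the range 1000 nM to 4500 nM.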

Compound 4, concentration for 50% growth inhibition: 5490 nM
Compound 4: middle estimate off by 2.6-fold (0.42 log units), on the low side; measured number above the stated range.
By their numbers in this assay, from the lowest: compounds 3, 2 and 1 (each within the scatter of the next); then compound 4.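

In this assay, going by these compounds alone, chloro in place of hydrogen on the aromatic carbon between two ring nitrogen atoms gives a 2.3-fold higher number from compound 2 to compound 4 (0.37 log units; beyond the scatter), the first step to lie beyond the scatter. This position therefore responds to substitution, and here the change weakens growth inhibition. The step is modest and rests on this one pair, and nothing available bears on the reason for it.

Going by these compounds, whether the shift is specific to chloro or would follow from other groups on this carbon remains open; an amine, a methoxy group or a methyl group at this position would help separate those readings. Also open, on these data alone, is whether the same chloro placed on the core of compound 1, which differs from compound 2 in its arm, would give a step of similar size and direction.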